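Thiophen-3-yl for furan-3-yl in two related series

The source may report more compounds than this note shows. Statements on the series, on what has been measured and on what is new or still open speak of the compounds shown alone.

Compound 1 `CC1=C(C(=O)OC(C)(C)C)C(c2ccoc2)NC(=S)N1` and compound 2 `CC1=C(C(=O)OC(C)(C)C)C(c2ccsc2)NC(=S)N1` share one core; compound 3 `CC1=C(C(N)=O)C(c2ccoc2)NC(=O)N1` and compound 4 `CC1=C(C(N)=O)C(c2ccsc2)NC(=O)N1` share another. The difference between the two cores is not broken down here. In an assay on membranes from CHO cells for displacement of a labelled ligand from adenosine receptor A1 (Homo sapiens), read by scintillation counting, with a stated time of 60 min, tested at 1 uM (on this read-out lower numbers stand for less inhibition and higher numbers for more inhibition at the one concentration tested (going by the name of the read-out)), compound 1 gives 18% and compound 2 gives 16%. The step of a number 2 percentage points lower from compound 1 to compound 2 (within the scatter) comes with the change (thiophen-3-yl in place of furan-3-yl on a saturated ring carbon). In this assay compound 3 gives 1%, the lowest of the three measured numbers.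

Compound 4 carries the same kind of change, (thiophen-3-yl in place of furan-3-yl on a saturated ring carbon), though here the saturated ring carbon is next to the ring atom that bears a carbamoyl group (3 heavy atoms), whereas in compound 1 it is next to the ring atom that bears a group of 7 heavy atoms. Since the earlier swap stayed within the scatter, the step of a number 1 percentage points higher from compound 3 to compound 4 (within the scatter) is expected to be equally small, resting on compound 3 at 1% as the starting point. Compound 4 is therefore estimated at 2% in this assay, with a range from -6% to 10%.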

Compound 4, a percentage reported as inhibition, at one concentration (the size of the read-out at that concentration, not a potency): 2%
Compound 4: the middle estimate sits on the measured number at the digits printed; the measured number falls inside the stated range.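

In this assay, thiophen-3-yl in place of furan-3-yl on a saturated ring carbon comes with a number 1 percentage points higher from compound 3 to compound 4 (within the scatter). Set beside the earlier step, the change carries from one core to the other with no difference that can be told apart: the same change on two cores in this assay, a number 2 percentage points lower (within the scatter) from compound 1 to compound 2 and a number 1 percentage points higher (within the scatter) from compound 3 to compound 4, 3 percentage points apart, within the scatter of two such steps. This holds for these two pairs only: each step rests on a single concentration and on numbers at the low end of the read-out, so neither gives a potency, and neither shows whether the swap would stay this small on a compound with much higher inhibition.

Still open, as far as these compounds go, is whether a six-membered aromatic ring such as phenyl or pyridyl on the saturated ring carbon would behave like these two five-membered rings. Also open, from the compounds shown here alone, is whether the swap stays as small when a carboxylic acid or an ester with a longer chain stands in place of the carbamoyl group.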